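Swapping a benzyl for a phenyl on a fused triazolopyrimidinone scaffold

This account rests on a few compounds, and the source may have more. Where it says the series, first, only, none or still open, it means among the compounds named here.

Measured compounds:
- compound 1, `Cc1ccc(-c2nc3[nH]c(-c4ccccc4)cc(=O)n3n2)cc1`: 3210 nM
- compound 2, `Cc1ccc(Cc2cc(=O)n3nc(Cc4ccc(Cl)cc4)nc3[nH]2)cc1`: 3020 nM

In a functional assay on Cortical neurone cells (Mus musculus, strain C57BL/6), read by FLIPR and calcium flux, with a stated time of 8 min (a higher number here means a weaker inhibitor, a lower number a stronger inhibitor), compound 1 gives 3210 nM and compound 2 gives 3020 nM. Compound 2 has the lowest of the two numbers, but compound 1 sits only a hair away, and the two values are within the scatter of each other, so the data show no order between them.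

Compound 3, `O=c1cc(-c2ccccc2)[nH]c2nc(Cc3ccc(Cl)cc3)nn12`, has not yet been measured in this assay. It differs from compound 2 in one place: phenyl in place of 4-methylbenzyl on an aromatic carbon. The reader will note that compound 1 already carries a phenyl at this position of the shared core and lands at essentially the same value as compound 2, so the two measured points give no sign that the phenyl-for-benzyl exchange moves the number far.

On that basis compound 3 is expected to show a step of a 1.0-fold lower number from compound 2 to compound 3 (0.00 log units; within the scatter) that stays within the scatter, in no firm direction. The estimate for compound 3 in this assay is 3000 nM, with a plausible range from 1200 nM to 7500 nM.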

Compound 3, half-maximal inhibitory concentration: 1830 nM
Compound 3: the middle estimate sits 1.6-fold (0.21 log units) above what was measured; measured number inside the range.
By their numbers in this assay, from the lowest: compounds 3, 2 and 1 (each within the scatter of the next).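

In this assay, going by these compounds alone, replacing 4-methylbenzyl with phenyl on this aromatic carbon, with the 4-chlorobenzyl on the other side of the shared core held fixed, gives a first clean reading of this exchange (a 1.7-fold lower number from compound 2 to compound 3 (0.22 log units; within the scatter)), and that step lies within the scatter, so the loss of the methyl and the shorter link leave no readable mark on the number here. With phenyl held at this position, the second single change, 4-chlorobenzyl in place of 4-methylphenyl on the other aromatic carbon, gives a step that also lies within the scatter (a 1.8-fold lower number from compound 1 to compound 3 (0.24 log units; within the scatter)), so neither of the two exchanges now readable separates its pair of compounds, where compounds 1 and 2 differ in two places and could not show this. Nothing available here accounts for these numbers.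

The compounds shown carry only carbon aromatic rings at this position, so it remains open whether a group of another kind there, such as a basic amine, a carboxylic acid or a longer alkyl chain, would move the number beyond the scatter. As far as these compounds go, it also remains open whether an unsubstituted benzyl would read differently from the phenyl of compound 3.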